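A Pyridine Ring in Place of Phenyl at the Sulfur

The source may hold more compounds than are shown below. What is called first, only, known or untested is meant among the compounds shown, and "the series" means these compounds.

Among the compounds with values here, compound 1 `CN1CCN(c2ccc(Nc3ncc4nc(SCc5ccccc5)n(C5CCOCC5)c4n3)cc2)CC1` is the stronger of the two compounds measured so far. In a functional assay on HCC827 cells (Homo sapiens) for antiproliferative activity, read by MTT assay, with a stated time of 72 h (on this read-out higher numbers stand for weaker inhibition and lower numbers for stronger inhibition), compound 1 gives 107 nM, while compound 2 `CN(C)CCN(C)c1ccc(Nc2ncc3nc([S+]([O-])c4ccccc4)n(C4CCOCC4)c3n2)cc1` gives 1330 nM in this assay, a gap well beyond the usual scatter. Compound 2 differs from compound 1 in several places at once, so its weaker number cannot be tied to any single change.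

Compound 3 `CN1CCN(c2ccc(Nc3ncc4nc(SCc5cccnc5)n(C5CCOCC5)c4n3)cc2)CC1` keeps everything in compound 1 except for one exchange: pyridin-3-yl in place of phenyl on a saturated chain carbon bound to a sulfur. Within the data shown here, no measured pair shows this exchange by itself, so the size of the step is open. The shared core and the link through the sulfur remain untouched. The step expected here is a 1.2-fold higher number from compound 1 to compound 3 (0.08 log units; within the scatter), meaning a change that is not expected to reach beyond the scatter in either direction. Compound 3 is therefore estimated at 130 nM, with a range from 50 nM to 350 nM.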

Compound 3, half-maximal inhibitory concentration: 500 nM
Estimate against measurement, compound 3: 3.8-fold (0.59 log units) below; measured number outside the range, above it.
By their numbers in this assay, from the lowest: compound 1; then compound 3; then compound 2.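

In this assay, the exchange of phenyl for pyridin-3-yl on a saturated chain carbon bound to a sulfur gives a 4.7-fold higher number from compound 1 to compound 3 (0.67 log units; beyond the scatter), the only single-place comparison among the compounds shown. This position is therefore sensitive to the make-up of the ring: the heavy-atom count stays the same and the new ring adds a hydrogen-bond acceptor, yet the inhibition weakens beyond the scatter. The available data offer no explanation for this weakening.

From the compounds shown here alone, it remains open whether another group on this chain carbon, such as pyridin-4-yl, 4-fluorophenyl or cyclohexyl, would match compound 1 or weaken inhibition as well. Also open, going by these compounds, is how a methylsulfanyl group or an amine would read in place of the whole benzylsulfanyl group.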